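Benzyl to Methyl on the Side Chain of Compound 1

The compounds below may be only part of what the source reports. "The series", "measured", "known", "first", "only" and "open" are said of these compounds alone.

Measured compounds:
compound 1, `Cc1cn([C@@H]2O[C@H](CO[Si](C)(C)C(C)(C)C)[C@@]3(OS(=O)(=O)C=C3NCCC(=O)OCc3ccccc3)[C@H]2O[Si](C)(C)C(C)(C)C)c(=O)n(C)c1=O`, 200000 nM
compound 2, `Cc1cn([C@@H]2O[C@H](CO[Si](C)(C)C(C)(C)C)[C@@]3(OS(=O)(=O)C=C3NC(N)=O)[C@H]2O[Si](C)(C)C(C)(C)C)c(=O)n(C)c1=O`, 11000 nM

In a functional assay on HEL cells (Homo sapiens) (a lower number here means that less compound is tolerated, a higher number that more compound is tolerated), compound 1 gives the highest of the two numbers shown; its nearest neighbour is compound 2, and the step of an 18-fold lower number from compound 1 to compound 2 (1.26 log units; beyond the scatter) is large. Going by the values given here, that step exchanges the whole 2-(benzyloxycarbonyl)ethyl chain for a carbamoyl group on the amine nitrogen, so it describes a different kind of alteration from the one that leads to compound 3.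

Compound 3, `COC(=O)CCNC1=CS(=O)(=O)O[C@@]12[C@@H](CO[Si](C)(C)C(C)(C)C)O[C@@H](n1cc(C)c(=O)n(C)c1=O)[C@@H]2O[Si](C)(C)C(C)(C)C`, is not yet measured in this assay. It differs from compound 1 by hydrogen in place of phenyl on a saturated chain carbon bound to an oxygen next to a carbonyl group, which reads, cut one bond further out, as benzyloxycarbonyl to methoxycarbonyl. Among the compounds with values here, no measured pair reports a change of this sort; the only measured step alters a larger portion of the chain. The benzyloxycarbonyl part is retained in its carbonyl and oxygen, and only the phenyl is lost, so a step within or near the scatter is expected, with the direction uncertain. The expected step is a 1.3-fold lower number from compound 1 to compound 3 (0.12 log units; within the scatter). For compound 3 the estimated value is 150000 nM, with a range from 50000 nM to 400000 nM.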

Compound 3, half-maximal cytotoxic concentration: 94000 nM
The estimate for compound 3 lay 1.6-fold (0.20 log units) above the measured number; the measured number falls inside the stated range.
By their numbers in this assay, from the lowest: compound 2; then compound 3; then compound 1.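

In this assay the loss of the phenyl alone gives a 2.1-fold lower number from compound 1 to compound 3 (0.33 log units; beyond the scatter) and so shows that this part of the side chain, on a saturated chain carbon bound to an oxygen next to a carbonyl group, has a small but readable bearing on the number. With the phenyl gone, the change on the amine nitrogen still gives an 8.5-fold higher number from compound 2 to compound 3 (0.93 log units; beyond the scatter) and thus accounts for the larger part of the distance between the carbamoyl compound and the benzyl ester, so the amine substituent as a whole matters more here than the phenyl by itself. Nothing in the material shown explains either step.

The compounds shown leave open whether the number in this assay would keep moving along the same line with an ethyl ester or a free carboxylic acid at the end of the chain, since only the benzyl and methyl esters can be compared. They also leave open how a longer chain between the amine nitrogen and the ester, or a simple primary amine at this position, would stand relative to the carbamoyl group.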